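A Chloro Added to Compound 3

The source may hold more compounds than are shown below. What is called first, only, known or untested is meant among the compounds shown, and "the series" means these compounds.

Of the compounds shown here, three have been tested in a functional assay on KB cells (Homo sapiens) for inhibition, read by MTT assay, with a stated time of 24 h, tested at 100 ug/mL; a higher number here means more inhibition of growth at the concentration tested, a lower number less inhibition of growth. Compound 1 (`O=C(CCCCC(S)CCS)Nc1cccc(C(F)(F)F)c1`) gives 30.5% there, and compound 2 (`CC(=O)SCCC(CCCCC(=O)Nc1cccc(Cl)c1)SC(C)=O`) gives 48.8%. Compound 3 (`O=C(CCCCC(CCSC(=O)c1ccccc1)SC(=O)c1ccccc1)Nc1ccccc1`) is reported as "not active" (no number reported). It therefore has no number of its own and stands apart from the two values that were recorded.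

Compound 4 (`O=C(CCCCC(CCSC(=O)c1ccccc1)SC(=O)c1ccccc1)Nc1ccc(Cl)cc1`) has not yet been measured. It departs from compound 3 in a single place: chloro in place of hydrogen on an aromatic carbon. The new group sits para to a large group, so that phenylcarbamoyl becomes (4-chlorophenyl)carbamoyl.

In this assay, a small upward step is expected from the standing of compound 3, and the result may yet come back without a number. The support for this is thin. Among the compounds with values here, compound 2 also carries a chloro on such a ring and gives 48.8%, but it differs from compound 3 elsewhere as well, and no measured pair isolates the effect of this change. For compound 4, the estimated inhibition is 20%, with an expected range from 3% to 45%.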

Compound 4, percent growth inhibition at one concentration: 5.78%
Beside the measured number, compound 4's estimate is 14.2 percentage points above it; the measured number falls inside the stated range.
By their numbers in this assay, from the lowest: compound 4; then compound 1; then compound 2.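

In this assay, within the data shown here, compound 4 gives 5.78% while compound 3 is reported as not active with no number, so no step between compound 3 and compound 4 can be read. The compounds shown leave open what chloro in place of hydrogen does in this assay on its own. No evidence on the cause of this result is available.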